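Ester variation on a vinylsulfonamide scaffold: benzyl replaces phenylethyl

The source may report more compounds than this note shows. Statements on the series, on what has been measured and on what is new or still open speak of the compounds shown alone.

Measured so far:
compound 1, `C=CS(=O)(=O)NC/C=C/c1cc(OC)cc(O)c1C(=O)OCC1CCCCC1`, 7880 nM
compound 2, `C=CS(=O)(=O)NC/C=C/c1cc(OC)cc(O)c1C(=O)OCC(C)c1ccccc1`, > 10000 nM

Of the compounds shown here, two have been tested in a functional assay on THP-1 cells (Homo sapiens) for antiproliferative activity, read by luminescence, with a stated time of 72 h; on this read-out higher numbers stand for weaker inhibition and lower numbers for stronger inhibition. Compound 1 is `C=CS(=O)(=O)NC/C=C/c1cc(OC)cc(O)c1C(=O)OCC1CCCCC1` and in this assay compound 1 gives 7880 nM. Compound 2 is `C=CS(=O)(=O)NC/C=C/c1cc(OC)cc(O)c1C(=O)OCC(C)c1ccccc1`, and for compound 2 this assay reports only a limit, > 10000 nM; this is the limit of > 10000 nM in this assay, at which 1 of the 2 values shown sits, so no exact number is known for compound 2. Among the measured compounds shown here, the one measured step, an at least 1.2-fold higher number from compound 1 to compound 2 (0.10 log units; that floor lies within the scatter), is therefore itself only a floor.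

Compound 3 is `C=CS(=O)(=O)NC/C=C/c1cc(OC)cc(O)c1C(=O)OCc1ccc(F)cc1`. It differs from compound 2 as 4-fluorophenyl in place of 1-phenylethyl on a saturated chain carbon bound to an oxygen next to a carbonyl group. For the measured compounds named here, no measured step covers this change directly; the single step from compound 1 to compound 2 shows only that swapping one ester substituent for another moved the number little, if at all. With so little to go on, compound 3 is expected to sit near the same region, with the step of an at least 1.2-fold lower number from compound 2 to compound 3 (0.09 log units; that floor lies within the scatter) estimated as small in either direction. The value of compound 3 is estimated at 8000 nM, within roughly 2500 nM to 25000 nM.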

Compound 3, half-maximal inhibitory concentration: 6550 nM
Compound 3: middle estimate off by 1.2-fold (0.09 log units), on the high side; the range from low to high includes it.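

In this assay compound 3 gives 6550 nM, the second exact number in this small set, so an exact comparison between two ester groups on the shared core can now be made. Exchanging cyclohexyl for 4-fluorophenyl gives a 1.2-fold lower number from compound 1 to compound 3 (0.08 log units; within the scatter), which means that at this place, on a saturated chain carbon bound to an oxygen next to a carbonyl group, the saturated ring and the fluorinated aromatic ring cannot be told apart in this assay. The exchange of 1-phenylethyl for 4-fluorophenyl gives an at least 1.5-fold lower number from compound 2 to compound 3 (0.18 log units; that floor lies within the scatter), and this step is only a floor, since the number for compound 2 is a limit: the limit of > 10000 nM in this assay, at which 1 of the 3 values shown sits.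

Whether the fluorine contributes anything remains open, as the plain benzyl ester, without fluorine, is not among the compounds shown. Also open, as far as these compounds go, is whether an ester carrying an amine, a carboxylic acid or a longer chain would move the number beyond the scatter, which none of the exact values shown here does.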